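The compounds below may be only part of what the source reports. "The series", "measured", "known", "first", "only" and "open" are said of these compounds alone.

Measured compounds:
compound 1 `Cc1cc(-c2ccccc2)n(/C(N)=N/S(=O)(=O)c2cc(C)c(Cl)cc2SCc2ccccc2C)n1`; in a functional assay on HeLa cells (Homo sapiens) for cytotoxicity, read by MTT assay, with a stated time of 72 h (on this read-out higher numbers stand for weaker inhibition and lower numbers for stronger inhibition), compound 1 gives 160000 nM
compound 2 `Cc1cc(-c2ccccc2)n(/C(N)=N/S(=O)(=O)c2cc(C)c(Cl)cc2SCc2ccccc2C(F)(F)F)n1`; compound 2 gives 215000 nM
compound 3 `Cc1cc(S(=O)(=O)/N=C(\N)n2nccc2-c2ccccc2)c(SCc2ccccc2C)cc1Cl`; compound 3 gives 17000 nM

Compound 3 holds the lowest number of the three: a 9.4-fold lower number from compound 1 to compound 3 (0.97 log units; beyond the scatter), and compound 2 lies further from it still. Compound 4 `Cc1ccc(CSc2cc(Cl)c(C)cc2S(=O)(=O)/N=C(\N)n2nccc2-c2ccccc2)cc1` differs from compound 3 by 4-methylphenyl in place of 2-methylphenyl on a saturated chain carbon bound to a sulfur. Of the measured steps, only a 1.3-fold higher number from compound 1 to compound 2 (0.13 log units; within the scatter) alters the 2-methylbenzyl group, and it stays within the scatter; a 9.4-fold lower number from compound 1 to compound 3 (0.97 log units; beyond the scatter) concerns the shared core and does not bear on this change. For the measured compounds named here, no measured step moves a methyl around that ring. A step of no change at the digits printed from compound 3 to compound 4 (within the scatter) is therefore expected, not beyond the scatter. Compound 4 is estimated at 17000 nM, with a range from 7000 nM to 45000 nM.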

Compound 4, half-maximal inhibitory concentration: 17000 nM
Compound 4: the middle estimate sits on the measured number at the digits printed; the measured number falls inside the stated range.
By their numbers in this assay, from the lowest: compounds 3 and 4 (each within the scatter of the next); then compounds 1 and 2 (each within the scatter of the next).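

Within this assay the methyl group on the benzyl ring can be moved from 2-methylbenzyl to 4-methylbenzyl on the core of compound 3 with no measurable consequence (no change at the digits printed from compound 3 to compound 4 (within the scatter)). For the compounds shown here, this is the first measured step that relocates a group on that ring; the earlier step on that ring (a 1.3-fold higher number from compound 1 to compound 2 (0.13 log units; within the scatter)) exchanged one group for another on a different core. Nothing available explains why these two isomers read alike. Still open, from the compounds shown here alone, is whether an amine or a carboxylic acid on that ring, or a longer chain in place of the methyl, would leave the number unchanged.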